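The source may hold more compounds than are shown below. What is called first, only, known or untested is meant among the compounds shown, and "the series" means these compounds.

Measured so far in an ADME assay on Vero cells (Chlorocebus sabaeus) for cytotoxicity; on this read-out lower numbers stand for higher toxicity in this test and higher numbers for lower toxicity in this test:
- Compound 1 `COc1ccc(-c2nc3cc(Cl)c(Cl)cc3[nH]2)c(N)c1` gives 75000 nM.
- Compound 2 `CN1CCN(CC(=O)Nc2ccc(-c3nc4cc(C(F)(F)F)ccc4n3C)cc2)CC1` gives > 100000 nM, which is a limit of the assay and not a number.
- Compound 3 `CC(=O)Nc1ccc(-c2nc3cc(C(F)(F)F)ccc3[nH]2)cc1` gives 50000 nM.

Compound 2 thus stands at the upper edge of what this assay reports; the limit of > 100000 nM in this assay, at which 1 of the 3 values shown sits, marks that one of the three values sits there. Among the compounds with values here, compound 1 and compound 3 both return numbers within the measurable window, and no step between any pair of these measured compounds is worked out, so the three values are only read side by side.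

Compound 4 `Cn1c(-c2ccc(NC(=O)CN3CCN(c4ccccc4)CC3)cc2)nc2cc(C(F)(F)F)ccc21` is not yet measured. It differs from compound 2 in one place: phenyl in place of methyl on an amine nitrogen in a ring. The rest of the molecule, including the shared core of compound 2 and the amide linker, is unchanged.

With compound 2 only at a limit, the step of an at least 1.6-fold lower number from compound 2 to compound 4 (0.22 log units; that floor lies within the scatter) is an expectation without a measured anchor; a modest shift toward lower numbers, possibly within the scatter, is expected. For compound 4 in this assay the estimate is 60000 nM, with a range from 20000 nM to 150000 nM.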

Compound 4, half-maximal cytotoxic concentration: 30000 nM
Estimate against measurement, compound 4: 2.0-fold (0.30 log units) above; the range from low to high includes it.
By their numbers in this assay, from the lowest: compounds 4, 3 and 1 (each within the scatter of the next, the first and the last beyond it). At a limit, above all of these: compound 2.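

In this assay, within the data shown here, phenyl in place of methyl on an amine nitrogen in a ring gives an at least 3.3-fold lower number from compound 2 to compound 4 (0.52 log units; beyond the scatter), the first step that can be read. This position is therefore not silent in this test: going from 4-methylpiperazin-1-yl to 4-phenylpiperazin-1-yl brings the read-out inside the measurable window, with compound 4 at 30000 nM. The step remains a floor and its full size is unknown, because one end of it is a limit: the limit of > 100000 nM in this assay, at which 1 of the 4 values shown sits.

Open, on these data alone, is whether a cyclohexyl or benzyl group on this nitrogen would give a number like that of compound 4, which would separate the aromatic ring from the added carbon count. Also open, as far as these compounds go, is whether a carboxylic acid or an amine on the phenyl ring would move the number back towards the limit.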